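This account rests on a few compounds, and the source may have more. Where it says the series, first, only, none or still open, it means among the compounds named here.

Measured compounds:
compound 1, `Oc1nc2nonc2nc1Nc1ccc(OCC2CC2)c(C(F)(F)F)c1`: 1800 nM
compound 2, `Oc1nc2nonc2nc1Nc1cccc(S(F)(F)(F)(F)F)c1`: 3700 nM
compound 3, `Oc1nc2nonc2nc1Nc1cccc(C(F)(F)F)c1`: 13300 nM

In an assay on mitochondria from L6 cells (Rattus norvegicus) for activation, with a stated time of 90 min (a lower number here means that less compound is needed, a higher number that more compound is needed for the effect), compound 3 gives 13300 nM, the highest of the three numbers. Both measured steps end at it: a 7.4-fold higher number from compound 1 to compound 3 (0.87 log units; beyond the scatter) and a 3.6-fold higher number from compound 2 to compound 3 (0.56 log units; beyond the scatter), each beyond the scatter.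

Compound 4 is `Oc1nc2nonc2nc1Nc1cccc(C(F)(F)F)c1F`. (fluoro in place of hydrogen on an aromatic carbon). Neither measured step resembles this change, since each swaps one group for another on the ring rather than adding a single fluorine, so no step beyond the scatter is expected in this assay. Compound 4 is therefore expected to give about 12000 nM, with a likely range from 5000 nM to 30000 nM. The expected step of a 1.1-fold lower number from compound 3 to compound 4 (0.04 log units; within the scatter) stays within the usual scatter.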

Compound 4, half-maximal effective concentration: 4900 nM
Compound 4: the middle estimate sits 2.4-fold (0.39 log units) above what was measured, and the stated range ends above it.
By their numbers in this assay, from the lowest: compound 1; then compounds 2 and 4 (each within the scatter of the next); then compound 3.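

In this assay, a single fluoro on an aromatic carbon, ortho to a trifluoromethyl group, gives a 2.7-fold lower number from compound 3 to compound 4 (0.43 log units; beyond the scatter) and so moves the number beyond the scatter. The earlier steps shown here involved larger groups, whereas this one shows that this position responds to the addition of a single fluorine atom. No measurement shown here explains the change.
From the compounds shown here alone, whether a chlorine, methyl or methoxy group at this same position would give a similar change remains open. So does whether adding the fluoro to compound 1 would lower its number too.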